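Replacing the hexylamino group of compound 3

The source may report more compounds than this note shows. Statements on the series, on what has been measured and on what is new or still open speak of the compounds shown alone.

In a functional assay on MCF7 cells (Homo sapiens) for inhibition, read by MTT assay, with a stated time of 48 h (on this read-out higher numbers stand for weaker inhibition and lower numbers for stronger inhibition), compound 1 `COc1ccc(/C=C/c2cc(OC)cc(OC)c2/C=C/C(=O)N2CCCCC2C)cc1` gives 4350 nM, compound 2 `COc1ccc(/C=C/c2cc(OC)cc(OC)c2/C=C/C(=O)N2CCCCC2)cc1` gives 6050 nM and compound 3 `CCCCCCNC(=O)/C=C/c1c(/C=C/c2ccc(OC)cc2)cc(OC)cc1OC` gives 5530 nM. Compound 3 therefore stands within the scatter of both others, and no ranking can be read from these numbers. Compound 4 `COc1ccc(/C=C/c2cc(OC)cc(OC)c2/C=C/C(=O)N2CCN(C)CC2)cc1` differs from compound 3 in one place, on a carbonyl carbon: 4-methylpiperazin-1-yl in place of hexylamino on a carbonyl carbon. Two measured steps changed the group at that same place, a 1.3-fold higher number from compound 1 to compound 3 (0.10 log units; within the scatter) and a 1.1-fold lower number from compound 2 to compound 3 (0.04 log units; within the scatter), and a third, a 1.4-fold higher number from compound 1 to compound 2 (0.14 log units; within the scatter), changed a ring carbon. All three stayed within the scatter. Among the compounds with values here, no measured compound carries 4-methylpiperazin-1-yl, so a step no larger than the scatter is expected in this assay, estimated as a 1.1-fold lower number from compound 3 to compound 4 (0.04 log units; within the scatter). The expected value for compound 4 is 5000 nM, with an estimated range of 2000 nM to 12000 nM.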

Compound 4, half-maximal inhibitory concentration: 2290 nM
Beside the measured number, compound 4's estimate is 2.2-fold (0.34 log units) above it; measured number inside the range.
By their numbers in this assay, from the lowest: compounds 4, 1, 3 and 2 (each within the scatter of the next, the first and the last beyond it).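

At this carbonyl carbon, changing the amide group can shift the number beyond the scatter: in this assay, 4-methylpiperazin-1-yl gives the first such steps (a 2.4-fold lower number from compound 3 to compound 4 (0.38 log units; beyond the scatter)) and (a 2.6-fold lower number from compound 2 to compound 4 (0.42 log units; beyond the scatter)). The step from 2-methylpiperidin-1-yl stays within the scatter (a 1.9-fold lower number from compound 1 to compound 4 (0.28 log units; within the scatter)), so compound 4 separates from only two of the three other compounds. No evidence here accounts for these steps. Still open, going by these compounds, is whether the second ring nitrogen or its methyl matters, which piperazin-1-yl without the methyl or morpholin-4-yl at the same carbonyl carbon could help separate.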